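This account rests on a few compounds, and the source may have more. Where it says the series, first, only, none or still open, it means among the compounds named here.

Compound 1, `COc1ccc(/C=C/C(=O)c2ccc(Nc3cc(C)nc4nc(SCc5nc6ccccc6[nH]5)nn34)cc2)cc1F`, gives 140 nM in a functional assay on SW-620 cells (Homo sapiens) for cytotoxicity, read by MTT assay, with stated times of 4 h and 72 h, tested at 2 uM; a lower number here means a stronger inhibitor, a higher number a weaker inhibitor.
Compound 2, `Cc1cc(Nc2ccc(C(=O)/C=C/c3ccc(OC(F)(F)F)cc3)cc2)n2nc(SCc3nc4ccccc4[nH]3)nc2n1`, gives 220 nM in this assay.
Compound 3, `Cc1cc(Nc2ccc(C(=O)/C=C/c3ccc(Cl)cc3)cc2)n2nc(SCc3nc4ccccc4[nH]3)nc2n1`, gives 230 nM in this assay.

Compound 1 holds the lowest of the three numbers, but the gaps are small: a 1.6-fold higher number from compound 1 to compound 2 (0.20 log units; within the scatter) and a 1.6-fold higher number from compound 1 to compound 3 (0.22 log units; within the scatter) both fall within the scatter, and a 1.0-fold higher number from compound 2 to compound 3 (0.02 log units; within the scatter) is smaller still, so the three compounds stand together on the shared core.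

The unmeasured compound 4, `Cc1cc(Nc2ccc(C(=O)/C=C/c3ccccc3F)cc2)n2nc(SCc3nc4ccccc4[nH]3)nc2n1`, differs from compound 1 as follows: 2-fluorophenyl in place of 3-fluoro-4-methoxyphenyl on a double-bonded chain carbon bound to a double-bonded chain carbon. The two measured steps that bear on this change are those exchanging the same group at the same place, from compound 1 to compound 2 and from compound 1 to compound 3. Each of them shifted the number only a little, and within the scatter, whichever group entered. The change to compound 4 is of the same kind, so no step beyond the scatter is expected in this assay, with at most a slight drift toward a higher number.

Compound 4 is therefore estimated at 200 nM, with a range from 100 nM to 420 nM. The expected step is a 1.4-fold higher number from compound 1 to compound 4 (0.15 log units; within the scatter).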

Compound 4, half-maximal inhibitory concentration: 250 nM
Compound 4: the middle estimate sits 1.3-fold (0.10 log units) below what was measured; measured number inside the range.
By their numbers in this assay, from the lowest: compounds 1, 2, 3 and 4 (each within the scatter of the next).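

Compound 4 shows that the place on a double-bonded chain carbon bound to a double-bonded chain carbon also accepts 2-fluorophenyl: with a 1.8-fold higher number from compound 1 to compound 4 (0.25 log units; within the scatter) in this assay, the methoxy group and its hydrogen-bond acceptor leave without a step beyond the scatter. Against the other two groups the picture is the same, with a 1.1-fold higher number from compound 3 to compound 4 (0.04 log units; within the scatter) and a 1.1-fold higher number from compound 2 to compound 4 (0.06 log units; within the scatter), so a group named at the 4 place of the phenyl, which compounds 1, 2 and 3 all carry, is not needed for compound 4 to stand with them on the shared core. Nothing given here accounts for how little these exchanges matter in this assay.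

As far as these compounds go, all four groups are phenyl rings carrying halogen or oxygen-linked substituents, so it stays open whether an amine, a carboxylic acid or an unsubstituted phenyl at this place would stand with them. From the compounds shown here alone, all four compounds also keep the same ethenyl link and the same core, so what a longer chain in place of that link would do in this assay is equally open.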